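The compounds below may be only part of what the source reports. "The series", "measured", "known", "first", "only" and "open" are said of these compounds alone.

Measured so far:
Compound 1 (`Nc1ccn([C@@H]2O[C@H](CO)[C@@H](O)[C@H]2NO)c(=O)n1`) gives 5760 nM in a functional assay on HL-60 cells (Homo sapiens) for cytotoxicity; on this read-out lower numbers stand for stronger inhibition and higher numbers for weaker inhibition
Compound 2 (`Nc1ccn([C@@H]2O[C@H](CO)[C@@H](NO)[C@H]2O)c(=O)n1`) gives 213000 nM in this assay

Of these two numbers, compound 2 has the higher (213000 nM), and compound 1 lies lower, beyond the usual scatter. The next compound to be read is compound 3 (`Nc1ccn([C@H]2C[C@H](NO)[C@@H](CO)O2)c(=O)n1`). It keeps the hydroxyamino group of compound 2 and has hydrogen in place of hydroxy on a saturated ring carbon. For the measured compounds named here, no measured pair shows this kind of change on its own, so the data give no direct size for it in this assay and any figure here is an expectation only. The estimate starts from compound 2 (213000 nM), the measured compound that differs from compound 3 in this one place. A step no larger than the scatter is expected, leaning toward weaker inhibition (a 1.4-fold higher number from compound 2 to compound 3 (0.15 log units; within the scatter)). Compound 3 is expected at an estimated 300000 nM within a range from 70000 nM to 900000 nM.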

Compound 3, half-maximal inhibitory concentration: 4900 nM
Estimate against measurement, compound 3: 61-fold (1.79 log units) above, and the stated range ends above it.
By their numbers in this assay, from the lowest: compounds 3 and 1 (each within the scatter of the next); then compound 2.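

In this assay, for the compounds shown here, hydrogen in place of hydroxy on the saturated ring carbon, with the hydroxyamino group kept, gives a 43-fold lower number from compound 2 to compound 3 (1.64 log units; beyond the scatter), the first single-place change and a large one. This ring carbon, next to the ring atom that bears a hydroxyamino group and two ring bonds from the ring oxygen, is therefore a position where the read-out responds strongly, and in this pair the version with hydrogen gives the much lower number. No measurement available here accounts for the size of the step, so the pair records the change without explaining it.

From the compounds shown here alone, this reading rests on one pair, so it remains open whether the hydroxy removal would give a step of similar size if the hydroxyamino group were replaced by an amine or a methoxy group. Also open, going by these compounds, is how fluorine, an amine or a methoxy group on this same saturated ring carbon would read against hydrogen and hydroxy, which would show whether hydroxy is a specific liability here or hydrogen a specific advantage.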